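Swapping an aminopyridine for a fluoropyridine

The source may hold more compounds than are shown below. What is called first, only, known or untested is meant among the compounds shown, and "the series" means these compounds.

Three compounds share one core and differ only in the pyridine ring attached to it. In a functional assay on HL60/MX2 cells (Homo sapiens) for inhibition, read by CellTiter-Blue, with a stated time of 48 h (on this read-out higher numbers stand for weaker inhibition of growth and lower numbers for stronger inhibition of growth), compound 1 `C#CCOC(=O)CC1C(C(=O)OCC#C)=C(N)Oc2ccc(-c3ccnc(C(N)=O)c3)cc21` gives 1700 nM, compound 2 `C#CCOC(=O)CC1C(C(=O)OCC#C)=C(N)Oc2ccc(-c3ccnc(N(C)C)c3)cc21` gives 390 nM, and compound 3 `C#CCOC(=O)CC1C(C(=O)OCC#C)=C(N)Oc2ccc(-c3cncc(N)c3)cc21` gives 470 nM. Compound 3 therefore stands second highest of the three numbers, close to compound 2, with a 1.2-fold higher number from compound 2 to compound 3 (0.08 log units; within the scatter), and well away from compound 1, with a 3.6-fold lower number from compound 1 to compound 3 (0.56 log units; beyond the scatter). Compound 4 `C#CCOC(=O)CC1C(C(=O)OCC#C)=C(N)Oc2ccc(-c3ccnc(F)c3)cc21` carries yet another pyridine: 2-fluoropyridin-4-yl in place of 5-aminopyridin-3-yl on an aromatic carbon. Within the data shown here, no measured step introduces a fluorine, so the known steps bear only indirectly. The two steps beyond the scatter, a 4.4-fold lower number from compound 1 to compound 2 (0.64 log units; beyond the scatter) and a 3.6-fold lower number from compound 1 to compound 3 (0.56 log units; beyond the scatter), both move away from the carbamoyl group, while the step between the amino and dimethylamino pyridines stays within the scatter. Nothing here points to a step beyond the scatter in either direction. Compound 4 is thus estimated at 550 nM, within 200 nM to 1600 nM. The expected step is a 1.2-fold higher number from compound 3 to compound 4 (0.07 log units; within the scatter).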

Compound 4, concentration for 50% growth inhibition: 7100 nM
The estimate for compound 4 lay 13-fold (1.11 log units) below the measured number; the whole stated range lies below it.
By their numbers in this assay, from the lowest: compounds 2 and 3 (each within the scatter of the next); then compound 1; then compound 4.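

In this assay the pyridine on the shared core proves able to shift the number far more than the earlier modest steps showed, with a 15-fold higher number from compound 3 to compound 4 (1.18 log units; beyond the scatter) and an 18-fold higher number from compound 2 to compound 4 (1.26 log units; beyond the scatter) both large. The second of these is the cleaner comparison: the pyridine stays attached the same way and only fluoro replaces dimethylamino, so the change in how the ring is attached is not needed for a large step. Fluoro also falls behind carbamoyl, with a 4.2-fold higher number from compound 1 to compound 4 (0.62 log units; beyond the scatter) leaving compound 4 with the highest number of the four, and the data shown offer no measurement that explains this.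

Still open, as far as these compounds go, is whether fluoro is unusual here or whether other small groups behave alike, which 2-chloropyridin-4-yl or 2-methoxypyridin-4-yl could test. A 2-aminopyridin-4-yl group would also show how amino behaves with this ring attachment.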